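A few compounds are considered here, and "the series" means these few. Any claim that something is new, unique, unknown or untested is made for them only; others in the source may bear on it.

Of the compounds shown here, three sharing a common core have been measured in a functional assay on MCF7 cells (Homo sapiens) for inhibition, read by MTT assay, with a stated time of 72 h; on this read-out higher numbers stand for weaker inhibition of growth and lower numbers for stronger inhibition of growth. Compound 1 `O=S(=O)(NCCCNCC1COc2ccccc2O1)c1cc(C(F)(F)F)cc(C(F)(F)F)c1` gives 2500 nM in this assay. Compound 3 `O=S(=O)(NCCCNCc1ccc(-c2ccccc2)cc1)c1cc(C(F)(F)F)cc(C(F)(F)F)c1` gives 1700 nM, a number within the usual scatter of that of compound 1. Compound 2 `O=S(=O)(NCCNCc1cccc2ccccc12)c1cc(C(F)(F)F)cc(C(F)(F)F)c1` gives 18000 nM, a number beyond the scatter above the other two and so standing for weaker inhibition of growth. Compound 1 thus holds the second highest of the three numbers; its nearest neighbour is compound 3, its furthest compound 2.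

Compound 4 `O=S(=O)(NCCCNCc1ccc(Cl)c(Cl)c1)c1cc(C(F)(F)F)cc(C(F)(F)F)c1` has not yet been measured in this assay. It differs from compound 1 in one place: 3,4-dichlorophenyl in place of 2,3-dihydro-1,4-benzodioxin-2-yl on a saturated chain carbon bound to an amine nitrogen. Among the compounds with values here, no measured pair isolates this kind of change, so its effect is not known from the data. The values of compound 1 and compound 3 lie within the scatter of each other even though they carry different groups on the same saturated chain carbon, which suggests that the group at this position is tolerant of variation. On that basis the step is expected to be a 1.3-fold lower number from compound 1 to compound 4 (0.10 log units; within the scatter), with no direction beyond the scatter. Compound 4 is therefore estimated at 2000 nM in this assay, with a range from 800 nM to 5000 nM.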

Compound 4, concentration for 50% growth inhibition: 2400 nM
The estimate for compound 4 lay 1.2-fold (0.08 log units) below the measured number; measured number inside the range.
By their numbers in this assay, from the lowest: compounds 3, 4 and 1 (each within the scatter of the next); then compound 2.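

In this assay, putting 3,4-dichlorophenyl in place of 2,3-dihydro-1,4-benzodioxin-2-yl on a saturated chain carbon bound to an amine nitrogen gives a 1.0-fold lower number from compound 1 to compound 4 (0.02 log units; within the scatter). This is the first pair shown that differs only at this place, so the tolerance there now rests on a direct comparison rather than on a comparison of compounds that differ elsewhere as well. The exchange removes the six-membered non-aromatic ring with its two oxygen atoms and the 2 hydrogen-bond acceptors, brings in two chlorine atoms, and still leaves the number within the scatter, yet nothing measured here explains why the two groups read alike.

From the compounds shown here alone, whether this tolerance extends to a plain phenyl, an amine or a carboxylic acid at the same place remains open, as does the separate contribution of each chlorine atom in 3,4-dichlorophenyl. Going by these compounds, it also remains open how a longer chain in the core of compound 1 would read on its own, and whether the tolerance seen here would hold in cells other than those of this single growth assay.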